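This account rests on a few compounds, and the source may have more. Where it says the series, first, only, none or still open, it means among the compounds named here.

Measured compounds:
Compound 1 `CCc1c(F)c(N)c2c(=O)cc(-c3ccc(N)c(F)c3)oc2c1F`: in a functional assay on HeLa cells (Homo sapiens) for cytotoxicity, read by neutral red uptake, with a stated time of 3 days (a higher number here means a weaker inhibitor, a lower number a stronger inhibitor), compound 1 gives > 100000 nM, which is a limit of the assay and not a number.
Compound 2 `Nc1ccc(-c2cc(=O)c3c(N)c(F)c(CO)c(F)c3o2)cc1F`: in this assay compound 2 gives 24000 nM.
Compound 3 `Nc1ccc(-c2cc(=O)c3c(N)c(F)c(N)c(F)c3o2)cc1F`: in this assay compound 3 gives 19000 nM.

Compound 1 thus stands only at a limit, (the limit of > 100000 nM in this assay, at which 1 of the 3 values shown sits), and no number is known for it. Compounds 2 and 3 both give numbers, and the steps from compound 1 to them are an at least 4.1-fold lower number from compound 1 to compound 2 (0.61 log units; beyond the scatter) and an at least 5.2-fold lower number from compound 1 to compound 3 (0.72 log units; beyond the scatter). Between compounds 2 and 3 the step is a 1.3-fold lower number from compound 2 to compound 3 (0.10 log units; within the scatter).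

Compound 4 `CCOC(=O)c1c(F)c(N)c2c(=O)cc(-c3ccc(N)c(F)c3)oc2c1F` is still to be measured in this assay. Its change from compound 1: ethoxycarbonyl in place of ethyl on an aromatic carbon. Both measured steps from compound 1 bear on this change, as each replaces a hydrocarbon group at or near the same aromatic carbon with a group carrying hydrogen-bond acceptors or donors, and each gave an at least modest lower number. Ethoxycarbonyl brings two acceptors and no donor, so a lower number than the limit of compound 1 is expected, of at least modest size, though how far it goes cannot be fixed because compound 1 sits only at the limit of > 100000 nM in this assay, at which 1 of the 3 values shown sits.

Compound 4 is therefore estimated to give 40000 nM, with a range from 15000 nM to 100000 nM. This estimate means an at least 2.5-fold lower number from compound 1 to compound 4 (0.39 log units; beyond the scatter).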

Compound 4, half-maximal inhibitory concentration: > 100000 nM
Compound 4 ended at the assay's limit (the forecaster's own chance of this, stated with the estimate: 35%); middle value at least 2.5-fold (0.39 log units) away from the limit.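

The step between compound 1 and compound 4 cannot be read, because in this assay both stand at the same limit of the assay and neither gives a number: the limit of > 100000 nM in this assay, at which 2 of the 4 values shown sit.

The result shows that replacing ethyl at this aromatic carbon does not by itself bring the number down from the limit, as ethoxycarbonyl gives an at least 5.2-fold higher number from compound 3 to compound 4 (0.72 log units; beyond the scatter) and an at least 4.1-fold higher number from compound 2 to compound 4 (0.61 log units; beyond the scatter). Hydrogen-bond acceptors on the entering group are therefore not enough, and the presence of a hydrogen-bond donor in hydroxymethyl and amino fits the compounds shown, with none going against it, though this rests on very few compounds.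

Going by these compounds, it remains open whether a carboxylic acid or a primary amide at this aromatic carbon, each keeping the carbonyl and adding a hydrogen-bond donor, would give a number in the range of compound 2 and compound 3 or stay at the limit. A longer chain ending in hydroxy, such as 2-hydroxyethyl, would test whether the donor still counts when it sits further from the shared core.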